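From 5-methylpyrazin-2-yl to 5-methoxypyrazin-2-yl

A few compounds are considered here, and "the series" means these few. Any claim that something is new, unique, unknown or untested is made for them only; others in the source may bear on it.

In an ADME assay on MDCKII-LE cells (Canis lupus familiaris) for permeability (on this read-out lower numbers stand for lower permeability and higher numbers for higher permeability), compound 1 `Cc1cnc(NC(=O)c2cc(Oc3cnc(C(=O)N(C)C)cn3)c3cc(C)oc3c2)cn1` gives 22.3 10^-6 cm/s. Compound 2 `CCN(C)C(=O)c1cnc(Oc2cc(C(=O)Nc3cnc(C)cn3)cc3oc(C)cc23)cn1` gives 24.1 10^-6 cm/s and compound 3 `Cc1cnc(NC(=O)c2cc(Oc3cnc(C(=O)N4CCCC4)cn3)c3cc(C)oc3c2)cn1` gives 15.8 10^-6 cm/s, which leaves compound 1 within the scatter of both.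

The three measured steps all alter the group on the carbonyl carbon that carries dimethylamino in compound 1. They are a 1.1-fold higher number from compound 1 to compound 2 (0.03 log units; within the scatter), a 1.4-fold lower number from compound 1 to compound 3 (0.15 log units; within the scatter) and a 1.5-fold lower number from compound 2 to compound 3 (0.18 log units; within the scatter), and all lie within the scatter.

Compound 4 `COc1cnc(NC(=O)c2cc(Oc3cnc(C(=O)N(C)C)cn3)c3cc(C)oc3c2)cn1` changes a different place: methoxy in place of methyl on an aromatic carbon. This is methoxy in place of methyl on an aromatic carbon, para to a large group. Among the compounds with values here, no measured compound carries this change, so the measured steps are only an indirect guide to it. They show that this assay did not move beyond the scatter across the three compounds, and no step beyond the scatter is expected here either.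

The estimated step is a 1.1-fold lower number from compound 1 to compound 4 (0.05 log units; within the scatter). The estimated value for compound 4 is 20 10^-6 cm/s, with an expected range of 10 10^-6 cm/s to 35 10^-6 cm/s.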

Compound 4, apparent permeability: 15.8 10^-6 cm/s
Compound 4: the middle estimate sits 1.3-fold (0.10 log units) above what was measured; low and high end bracket the measured number.
By their numbers in this assay, from the lowest: compounds 3, 4, 1 and 2 (each within the scatter of the next).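

In this assay, methoxy in place of methyl on the aromatic carbon gives a 1.4-fold lower number from compound 1 to compound 4 (0.15 log units; within the scatter). The earlier steps shown here touched only the group on the carbonyl carbon, so this result extends the picture to the other end of the molecule: the (5-methylpyrazin-2-yl)carbamoyl group can become (5-methoxypyrazin-2-yl)carbamoyl, which adds one hydrogen-bond acceptor, with the read-out staying within the scatter of compound 1. No supporting measurement is available to explain the size of this step.

Open, on these data alone, is whether an ethoxy group, a longer chain, or an amine on this aromatic carbon would move the number beyond the scatter. Also open, as far as these compounds go, is whether methoxy in place of methyl gives a similar step when the carbonyl carbon carries pyrrolidin-1-yl, as in compound 3.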